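A few compounds are considered here, and "the series" means these few. Any claim that something is new, unique, unknown or untested is made for them only; others in the source may bear on it.

Series notes. For the measured compounds named here, compound 2 `COc1cccc(-n2cc(COc3ccc4c(c3)CCC4)nn2)c1` is the only member of the set with a number: in an ADME assay on HEK293 cells (Homo sapiens) for inhibition, read by MTT assay, with a stated time of 48 h, tested at 25 uM (a higher number here means more inhibition at the concentration tested (going by the name of the read-out), a lower number less inhibition), compound 2 gives 25.8%. Going by the values given here, compound 1 `CCc1ccc(NC(=O)Cn2cc(COc3ccc4c(c3)CCC4)nn2)cc1` in this assay gives "not determined" (no result reported), and compound 3 `O=C(Cn1cc(COc2ccc3c(c2)CCC3)nn1)Nc1ccc(F)cc1` in this assay gives "not determined" (no result reported); both share the same core as compound 2, so no step between measured compounds exists and no direction can be read from the set itself. Compound 4 `Fc1ccccc1-n1cc(COc2ccc3c(c2)CCC3)nn1` is the open member, differing from compound 2 as follows: 2-fluorophenyl in place of 3-methoxyphenyl on an aromatic nitrogen. With nothing to go by, the step in this assay is expected to be a number 0.8 percentage points lower from compound 2 to compound 4 (within the scatter), a change expected to stay within the usual scatter. Compound 4 is accordingly estimated at 25%, with a range from 5% to 45%.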

Compound 4, a percentage reported as inhibition, at one concentration (the size of the read-out at that concentration, not a potency): 21%
Beside the measured number, compound 4's estimate is 4 percentage points above it; low and high end bracket the measured number.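

In this assay, 2-fluorophenyl in place of 3-methoxyphenyl on an aromatic nitrogen gives a number 4.8 percentage points lower from compound 2 to compound 4 (within the scatter), so this read-out does not separate the two groups at this position. For the compounds shown here, this is the only step that can be read in the set, and it covers a single pair of substituted phenyl groups. No measured property bears on this result.

Steps involving compound 1 and compound 3 cannot be read. Going by these compounds, whether a phenyl group carrying an amine or a carboxylic acid at this position would give a step beyond the scatter remains open.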